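Swapping the aniline ring of a thiourea-linked quinazoline

The source may report more compounds than this note shows. Statements on the series, on what has been measured and on what is new or still open speak of the compounds shown alone.

Of the compounds shown here, two have so far been tested in a functional assay on NCI-H1975 cells (Homo sapiens) for antiproliferative activity, read by MTT assay, with a stated time of 72 h; a lower number here means a stronger inhibitor, a higher number a weaker inhibitor. Compound 1, `COc1cc2ncnc(Nc3ccc(Cl)c(C(F)(F)F)c3)c2cc1OCCCCC(=O)Nc1ccc(S(N)(=O)=O)cc1`, gives 3220 nM. Compound 2, `NS(=O)(=O)c1ccc(NC(=S)Nc2ccc3ncnc(Nc4ccc(F)c(Br)c4)c3c2)cc1`, gives 9980 nM, the higher of the two numbers; the gap between compound 1 and compound 2 is wider than the usual scatter, so compound 2 is the weaker of the pair. For the measured compounds named here, no single-point step between measured compounds is available, so nothing measured shows how this assay responds to a change at the aniline ring.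

Compound 3, `CCc1ccc(Nc2ncnc3ccc(NC(=S)Nc4ccc(S(N)(=O)=O)cc4)cc23)cc1`, has not yet been measured. It differs from compound 2 in one place: 4-ethylphenyl in place of 3-bromo-4-fluorophenyl on a nitrogen on an aromatic ring. Going by the values given here, with no measured step of this kind to rest on, the expected change from compound 2 to compound 3 is a 1.5-fold higher number from compound 2 to compound 3 (0.18 log units; within the scatter), a modest move towards a higher number, though a result within the scatter would not be surprising. Compound 3 is estimated at 15000 nM, with a range from 4000 nM to 50000 nM.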

Compound 3, half-maximal inhibitory concentration: 38700 nM
Compound 3: the middle estimate sits 2.6-fold (0.41 log units) below what was measured; measured number inside the range.
By their numbers in this assay, from the lowest: compound 1; then compound 2; then compound 3.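

For the compounds shown here, this is the first measured step at the aniline ring: in this assay, putting 4-ethylphenyl in place of 3-bromo-4-fluorophenyl on the nitrogen gives a 3.9-fold higher number from compound 2 to compound 3 (0.59 log units; beyond the scatter) and so a weaker compound. The assay therefore responds to what this nitrogen carries, even though the two groups have the same heavy-atom count and each is a single six-membered aromatic ring of carbon. No available measurement explains why the number rises.

A single step changes three things at once, so the loss of bromine, the loss of fluorine and the gain of ethyl cannot be told apart. A plain phenyl, a 4-fluorophenyl or a 3-bromophenyl on the same nitrogen would begin to separate these contributions.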